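The source may hold more compounds than are shown below. What is called first, only, known or untested is meant among the compounds shown, and "the series" means these compounds.

Measured in an ADME assay on Huh-7 cells (Homo sapiens) for cytotoxicity, read by XTT assay, with a stated time of 3 days, tested at 20 uM; on this read-out lower numbers stand for a stronger effect and higher numbers for a weaker effect at the one concentration tested:
compound 1 `Fc1ccc(-c2cc(-c3ccc4cc(F)ccc4n3)n(-c3ccccc3)n2)cc1` gives 88.1%;
compound 2 `COc1ccc(-c2cc(-c3ccc4cc(F)ccc4n3)n(-c3ccccc3)n2)cc1` gives 104%;
compound 3 `COc1ccc(-n2nc(-c3ccc(F)cc3)cc2-c2ccc3cc(F)ccc3n2)cc1` gives 89.1%.

Compound 2 arises from compound 1 through (methoxy in place of fluoro on an aromatic carbon), and in this assay this gave a number 15.9 percentage points higher from compound 1 to compound 2 (beyond the scatter). The core of compound 3 differs from that of compound 1 by methoxy in place of hydrogen on an aromatic carbon, which in this assay gave a number 1 percentage points higher from compound 1 to compound 3 (within the scatter). Compound 4 `COc1ccc(-c2cc(-c3ccc4cc(F)ccc4n3)n(-c3ccc(OC)cc3)n2)cc1` has not been measured; it differs from compound 3 by methoxy in place of fluoro on an aromatic carbon, the same change that turns compound 1 into compound 2, made at the same kind of place. Because the earlier step was a number 15.9 percentage points higher from compound 1 to compound 2 (beyond the scatter), compound 4 is expected to show a step of about a number 12.9 percentage points higher from compound 3 to compound 4 (beyond the scatter) in this assay. The estimate for compound 4 in this assay is 102%, with a likely range from 88% to 115%.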

Compound 4, a percentage reported as activity, at one concentration (the size of the read-out at that concentration, not a potency): 95.8%
For compound 4 the middle estimate is 6.2 percentage points above the measured one; the measured number falls inside the stated range.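

In this assay, methoxy in place of fluoro gave a number 6.7 percentage points higher from compound 3 to compound 4 (within the scatter), and set beside the earlier step this reads: the same change on two cores in this assay, a number 15.9 percentage points higher (beyond the scatter) from compound 1 to compound 2 and a number 6.7 percentage points higher (within the scatter) from compound 3 to compound 4, 9.2 percentage points apart, within the scatter of two such steps. Methoxy in place of hydrogen gave a number 8.2 percentage points lower from compound 2 to compound 4 (within the scatter), and the comparison with its earlier step reads: the same change on two cores in this assay, a number 1 percentage points higher (within the scatter) from compound 1 to compound 3 and a number 8.2 percentage points lower (within the scatter) from compound 2 to compound 4, 9.2 percentage points apart, within the scatter of two such steps. Both changes thus carried from one core to the other without a gap beyond the scatter, but each rests on a single pair of steps, which does not establish a fixed step size or show that either change would carry to any further core.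

The compounds shown leave open how other groups at this place, such as an amine or a carboxylic acid, would read in this assay. They also leave open whether a longer chain in place of methoxy would follow the same course.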